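The compounds below may be only part of what the source reports. "The series", "measured", "known", "first", "only" and "open" are said of these compounds alone.

Of the compounds shown here, two built on one shared core have been tested for toxicity toward a human cell line. In an ADME assay on KB cells (Homo sapiens) for cytotoxicity, read by MTT assay, with a stated time of 72 h (on this read-out higher numbers stand for lower toxicity in this test and lower numbers for higher toxicity in this test), compound 1 `Cc1ccc(Nc2nc(-c3ccccn3)cs2)cc1C` gives 54400 nM, while compound 2 `COc1ccc(Nc2nc(-c3ccccn3)cs2)cc1` gives 140000 nM. Among the measured compounds shown here, of these two numbers compound 2 stands highest, and its gap to compound 1, the only neighbour, lies beyond the usual scatter, so compound 2 is the less toxic of the pair in this test.

Compound 3 `Cc1ccc(Nc2nc(-c3ccccn3)cs2)cc1` has not yet been measured. Against compound 2 it differs in one place: methyl in place of methoxy on an aromatic carbon. For the measured compounds named here, no step of this kind between measured compounds is known, so its size is uncertain. A small step toward higher toxicity in this assay, near the edge of the scatter, is expected, because compound 1 with its methyl groups gives 54400 nM. Compound 3 is therefore estimated at 80000 nM, within a range from 35000 nM to 180000 nM. The expected step of a 1.8-fold lower number from compound 2 to compound 3 (0.24 log units; within the scatter) is thus a modest one.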

Compound 3, half-maximal cytotoxic concentration: 64100 nM
Estimate against measurement, compound 3: 1.2-fold (0.10 log units) above, and the stated range covers the measured number.
By their numbers in this assay, from the lowest: compounds 1 and 3 (each within the scatter of the next); then compound 2.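

In this assay, methyl in place of methoxy on the aromatic carbon para to a large group gives a 2.2-fold lower number from compound 2 to compound 3 (0.34 log units; beyond the scatter), so this one replacement is enough to shift the number past the usual scatter. By contrast, hydrogen in place of methyl on an aromatic carbon gives a 1.2-fold higher number from compound 1 to compound 3 (0.07 log units; within the scatter), so that extra methyl of compound 1 leaves no difference that can be told apart from compound 3. No measurement at hand gives a reason for either step. From the compounds shown here alone, it remains open whether a hydroxyl, a chlorine atom or a longer chain such as ethoxy on the same carbon would read like methoxy or like methyl. Going by these compounds, it is also open whether the methoxy-to-methyl step would keep its size on a different core.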